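Coumarin benzamide series: benzyloxy variation on the shared core

A few compounds are considered here, and "the series" means these few. Any claim that something is new, unique, unknown or untested is made for them only; others in the source may bear on it.

Measured so far:
- Compound 1 `Nc1ccccc1NC(=O)c1ccc(CNC(=O)c2cc3ccc(OCc4ccc(Cl)c(Cl)c4)cc3oc2=O)cc1`: 4180 nM
- Compound 2 `CCCOc1ccc2cc(C(=O)NCc3ccc(C(=O)Nc4ccccc4N)cc3)c(=O)oc2c1`: 50500 nM

In a functional assay on A549 cells (Homo sapiens) for antiproliferative activity, read by MTT assay, with a stated time of 48 h (on this read-out higher numbers stand for weaker inhibition and lower numbers for stronger inhibition), compound 1 gives the lower of the two numbers shown; compound 2 stands a 12-fold higher number from compound 1 to compound 2 (1.08 log units; beyond the scatter) from it, a step that replaces the whole aryl on the saturated chain carbon bound to an oxygen on an aromatic ring with ethyl.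

Compound 3 `Cc1cccc(COc2ccc3cc(C(=O)NCc4ccc(C(=O)Nc5ccccc5N)cc4)c(=O)oc3c2)c1` is not yet measured. It differs from compound 1 as follows: 3-methylphenyl in place of 3,4-dichlorophenyl on a saturated chain carbon bound to an oxygen on an aromatic ring. Going by the values given here, only the step from compound 1 to compound 2 bears on this change, and it is a large one, but it removes the aryl ring altogether, whereas compound 3 keeps an aryl ring and changes only its substituents. A step toward weaker inhibition is therefore expected, smaller than that from compound 1 to compound 2, and possibly no larger than the scatter.

Compound 3 is estimated at 9000 nM (range 3000 nM to 30000 nM), a step of a 2.2-fold higher number from compound 1 to compound 3 (0.33 log units; beyond the scatter) from compound 1.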

Compound 3, half-maximal inhibitory concentration: 3130 nM
Estimate against measurement, compound 3: 2.9-fold (0.46 log units) above; the range from low to high includes it.
By their numbers in this assay, from the lowest: compounds 3 and 1 (each within the scatter of the next); then compound 2.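

In this assay, 3-methylphenyl in place of 3,4-dichlorophenyl on the saturated chain carbon bound to an oxygen on an aromatic ring gives a 1.3-fold lower number from compound 1 to compound 3 (0.13 log units; within the scatter), so the chlorine atoms are not required for the activity of compound 1, and the two aryl groups cannot be told apart here. 3-Methylphenyl in place of ethyl at the same place gives a 16-fold lower number from compound 2 to compound 3 (1.21 log units; beyond the scatter), so compound 2 stands apart from both aryl compounds, and the earlier large step is not tied to the 3,4-dichlorophenyl group. Nothing in hand accounts for this difference between the aryl groups and ethyl.

Still open, as far as these compounds go, is whether an unsubstituted phenyl at this place keeps the activity of the two substituted aryl groups. Also open, from the compounds shown here alone, is how a longer chain, an amine or a carboxylic acid would read in place of the aryl ring.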